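Swapping the aryl group on a low-toxicity compound

This account rests on a few compounds, and the source may have more. Where it says the series, first, only, none or still open, it means among the compounds named here.

- compound 1 `Cc1nc(C(NC(=O)C(=O)Nc2ccc(Cl)c(F)c2)C2CCCCN2)sc1CO`: 58400 nM
- compound 2 `Cc1ccc(NC(=O)C(=O)NC(c2nc(C)c(CO)s2)C2CCCCN2)cc1F`: > 88000 nM (a limit of the assay, not a number)

Cell toxicity was followed in an ADME assay on TZM-b1 cells (Homo sapiens) for cytotoxicity, read by XTT assay, with a stated time of 3 days; on this read-out higher numbers stand for lower toxicity in this test and lower numbers for higher toxicity in this test. On these data alone, compound 2 gives only a limit there, so its exact position is unknown. The whole measured set contains (the limit of > 88000 nM in this assay, at which 1 of the 2 values shown sits).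

The next structure is compound 3 `Cc1nc(C(NC(=O)C(=O)Nc2ccc(F)cc2F)C2CCCCN2)sc1CO`. Its change is 2,4-difluorophenyl in place of 3-fluoro-4-methylphenyl on an amide-type nitrogen, with 2,4-difluorophenyl in place of 3-fluoro-4-methylphenyl on an amide-type nitrogen. The rest of the molecule stays the same.

For the measured compounds named here, only one measured step bears on this: an at least 1.5-fold higher number from compound 1 to compound 2 (0.17 log units; that floor lies within the scatter), with methyl in place of chloro on an aromatic carbon. That step is small, and its floor lies within the scatter, so it gives no reason to expect a large shift in this assay. It also involves a different exchange, which makes it only a loose guide. The expected step is an at least 1.2-fold lower number from compound 2 to compound 3 (0.09 log units; that floor lies within the scatter), which is an estimate that stays within the scatter and has no firm direction. For compound 3 the estimated value is 70000 nM, with an expected range of 35000 nM to 130000 nM.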

Compound 3, half-maximal cytotoxic concentration: > 87000 nM
Compound 3: no number, only a limit; the forecaster's own chance of this, stated with the estimate: 40%; at least 1.2-fold (0.09 log units) between middle value and limit.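

In this assay compound 3 gives > 87000 nM, which is a limit of the assay and not a number. For the compounds shown here, this shows that a second, different aryl group on the amide-type nitrogen, one carrying only fluorine with neither the chloro nor the methyl of the earlier compounds, also ends at a limit rather than a measured number, as compound 2 does, while compound 1 is the one compound here with a measured number. Against the 4-chloro-3-fluorophenyl group, 2,4-difluorophenyl gives an at least 1.4-fold higher number from compound 1 to compound 3 (0.17 log units; that floor lies within the scatter), a floor that fixes no true size, and the step between the two compounds that end at limits cannot be read.

On these data alone, how far compound 2 and compound 3 really lie from the top of the test range stays unknown, so neither can be ranked against the other. Also open, as far as these compounds go, is whether a different kind of group on this nitrogen, such as a phenyl ring bearing a carboxylic acid or an amine, or a longer alkyl chain in place of the ring, would bring the number down into the measurable range.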